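A Phenyl Group Added to the Hydrazone Nitrogen

A few compounds are considered here, and "the series" means these few. Any claim that something is new, unique, unknown or untested is made for them only; others in the source may bear on it.

Of the compounds shown here, three sharing one core have been tested in a functional assay on HCT-116 cells (Homo sapiens) for cytotoxicity, read by sulforhodamine B assay, with a stated time of 24 h; on this read-out higher numbers stand for weaker inhibition and lower numbers for stronger inhibition. Compound 1 `O=C1Nc2ccc(S(=O)(=O)N3CCOCC3)cc2/C1=N/c1ccc(Br)cc1` gives 15300 nM, compound 2 `O=C1Nc2ccc(S(=O)(=O)N3CCOCC3)cc2/C1=N/c1ccc(O)cc1` gives 27300 nM, and compound 3 `N/N=C1\C(=O)Nc2ccc(S(=O)(=O)N3CCOCC3)cc21` gives 36300 nM, the highest of the three; its gap to compound 2 is within the scatter, while a 2.4-fold higher number from compound 1 to compound 3 (0.38 log units; beyond the scatter) lies beyond it. Compound 4 `O=C1Nc2ccc(S(=O)(=O)N3CCOCC3)cc2/C1=N/Nc1ccccc1` differs from compound 3 by phenyl in place of hydrogen on an amine nitrogen. Among the compounds with values here, no measured step matches this exactly, but a 2.4-fold higher number from compound 1 to compound 3 (0.38 log units; beyond the scatter) and a 1.3-fold higher number from compound 2 to compound 3 (0.12 log units; within the scatter) show that an aryl group attached to the double-bonded nitrogen went with lower numbers than the plain amino of compound 3. A modest lowering is therefore expected for compound 4, a 2.0-fold lower number from compound 3 to compound 4 (0.30 log units; within the scatter), giving an estimated 18000 nM with a range of 7000 nM to 45000 nM.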

Compound 4, half-maximal inhibitory concentration: 10500 nM
Estimate against measurement, compound 4: 1.7-fold (0.23 log units) above; measured number inside the range.
By their numbers in this assay, from the lowest: compounds 4, 1, 2 and 3 (each within the scatter of the next, the first and the last beyond it).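

In this assay, phenyl in place of hydrogen on the amine nitrogen brings a 3.5-fold lower number from compound 3 to compound 4 (0.54 log units; beyond the scatter), so an aromatic ring lowers the number here even when this amine nitrogen is kept in the link. Anilino also gives a 2.6-fold lower number from compound 2 to compound 4 (0.41 log units; beyond the scatter), but against 4-bromophenyl it gives a 1.5-fold lower number from compound 1 to compound 4 (0.16 log units; within the scatter), so these two groups cannot be told apart in this assay. Nothing shown gives a reason for these steps. From the compounds shown here alone, how a methoxy group or a carboxylic acid on the phenyl ring of compound 4 would change the number remains open.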